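The source may hold more compounds than are shown below. What is called first, only, known or untested is meant among the compounds shown, and "the series" means these compounds.

Measured so far in a functional assay on NCI-H460 cells (Homo sapiens) for cytotoxicity, read by MTT assay, with a stated time of 96 h; on this read-out higher numbers stand for weaker inhibition and lower numbers for stronger inhibition:
- compound 1 `CNc1nc(C)c2cc(-c3cnc(OC)c(NS(=O)(=O)c4ccc(F)cc4F)c3)cc(OC3CCOCC3)c2n1`: 59 nM
- compound 2 `CCNc1nc(C)c2cc(-c3cnc(OC)c(NS(=O)(=O)c4ccc(F)cc4F)c3)cc(OC3CCOCC3)c2n1`: 240 nM
- compound 3 `COc1ncc(-c2cc(OC3CCOCC3)c3nc(N(C)C)nc(C)c3c2)cc1NS(=O)(=O)c1ccc(F)cc1F`: 4300 nM

Compound 1 holds the lowest number of the three, so it is the most potent in this assay. Its nearest neighbour is reached by a 4.1-fold higher number from compound 1 to compound 2 (0.61 log units; beyond the scatter), and its furthest by a 73-fold higher number from compound 1 to compound 3 (1.86 log units; beyond the scatter). The third step, an 18-fold higher number from compound 2 to compound 3 (1.25 log units; beyond the scatter), is also large.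

Compound 4 `CNc1nc(C)c2cc(-c3cnc(OC)c(NS(=O)(=O)c4ccc(F)cc4F)c3)cc(OCC3CCOCC3)c2n1` keeps everything in compound 1 except one group: (oxan-4-yl)methyl in place of oxan-4-yl on an oxygen on an aromatic ring. Within the data shown here, none of the measured steps touches that place, since all three alter the amino group on the shared core. They therefore bear on the question only indirectly. They show that small additions elsewhere on this core can move the number, and that the size of the move varies widely. The closest guide in size is the small addition in a 4.1-fold higher number from compound 1 to compound 2 (0.61 log units; beyond the scatter), while the large 73-fold higher number from compound 1 to compound 3 (1.86 log units; beyond the scatter) warns of a wider outcome. A modest move towards a higher number is therefore expected, though the data cannot fix its direction firmly. The expected change is a 2.2-fold higher number from compound 1 to compound 4 (0.34 log units; beyond the scatter).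

For compound 4 the estimate is 130 nM, with an expected range from 35 nM to 550 nM.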

Compound 4, half-maximal inhibitory concentration: 400 nM
Estimate against measurement, compound 4: 3.1-fold (0.49 log units) below; measured number inside the range.
By their numbers in this assay, from the lowest: compound 1; then compounds 2 and 4 (each within the scatter of the next); then compound 3.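

In this assay, the group on this oxygen proves to matter: replacing oxan-4-yl with (oxan-4-yl)methyl gives a 6.8-fold higher number from compound 1 to compound 4 (0.83 log units; beyond the scatter), even though the ring and the counts of hydrogen-bond donors and acceptors stay the same. The earlier compounds shown here differed only in the amino group on the shared core, whereas compound 4 shows that the number also responds to a change on the other side of the ether oxygen, from (oxan-4-yl)oxy to (oxan-4-yl)methoxy. No measurement at hand accounts for this step.

With only one change at this place, the compounds shown leave open whether a longer chain, such as (oxan-4-yl)ethyl, would carry the number further in the same direction, and whether a piperidine ring with its amine nitrogen, or a plain methoxy group, would behave like oxan-4-yl or like (oxan-4-yl)methyl. They also leave open whether (oxan-4-yl)methyl would produce a step of similar size on the ethylamino or dimethylamino versions of the core.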